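This account rests on a few compounds, and the source may have more. Where it says the series, first, only, none or still open, it means among the compounds named here.

Measured so far in an ADME assay on L929 cells (Mus musculus) for antiproliferative activity, read by CCK-8 assay, with a stated time of 48 h; on this read-out lower numbers stand for stronger inhibition and higher numbers for weaker inhibition:
compound 1 `O=c1c2ccccc2[se]n1-c1nc(SCc2ccc(F)cc2)n[nH]1`: > 50000 nM, which is a limit of the assay and not a number.
compound 2 `O=c1c2ccccc2[se]n1-c1nc(SCc2ccc([N+](=O)[O-])cc2)n[nH]1`: 7430 nM.

Compound 1 stands only as a limit in this assay. Going by the values given here, the one measured step, an at least 6.7-fold lower number from compound 1 to compound 2 (0.82 log units; beyond the scatter), concerns nitro in place of fluoro on an aromatic carbon. Compound 3 `CCCCSc1n[nH]c(-n2[se]c3ccccc3c2=O)n1` differs from compound 1 by propyl in place of 4-fluorophenyl on a saturated chain carbon bound to a sulfur. Among the compounds with values here, no measured step covers this change, so no shift beyond the scatter is expected from the limit where compound 1 sits. The expected step is a number no higher from compound 1 to compound 3 (the limit leaves the size open). Compound 3 is estimated at 50000 nM, within 15000 nM to 160000 nM.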

Compound 3, half-maximal inhibitory concentration: 30400 nM
The estimate for compound 3 lay 1.6-fold (0.22 log units) above the measured number, within the range that was stated.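

In this assay compound 3, with propyl in place of 4-fluorophenyl on a saturated chain carbon bound to a sulfur, gives 30400 nM and shows that an aromatic ring is not needed here for a measurable number. The step (an at least 1.6-fold lower number from compound 1 to compound 3 (0.21 log units; that floor lies within the scatter)) gives only a floor, so no real change can be claimed from it. Compound 1 remains a limit and not a number: the limit of > 50000 nM in this assay, at which 1 of the 3 values shown sits.

Going by these compounds, whether a longer chain at this place would lower the number remains open. So does the effect of an amine or a carboxylic acid at the chain end.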